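Swapping an Isobutyl for a Trifluoromethylfuran

The source may hold more compounds than are shown below. What is called first, only, known or untested is meant among the compounds shown, and "the series" means these compounds.

Of the compounds shown here, two have so far been measured in an assay on HEK293 cells for inhibition of Voltage-dependent T-type calcium channel subunit alpha-1G (Homo sapiens), read by FLIPR and calcium flux, with a stated time of 3 min; on this read-out higher numbers stand for weaker inhibition and lower numbers for stronger inhibition. Compound 1, `C[C@@H]1CN(Cc2ccccc2)c2nc(C(F)(F)F)ccc2[C@H](C)N1C(=O)NCc1ccccc1`, gives 57 nM in this assay. Compound 2, `COc1ccc(CNC(=O)N2[C@H](C)CN(CCC(C)C)c3cnccc3[C@@H]2C)cc1`, gives 76 nM; this is the higher of the two numbers, but the two values lie within the scatter of each other, so neither compound can be called the stronger inhibitor on this evidence. Compound 3, `COc1ccc(CNC(=O)N2[C@H](C)CN(Cc3ccc(C(F)(F)F)o3)c3cnccc3[C@@H]2C)cc1`, has not yet been measured. It differs from compound 2 in a single place: 5-(trifluoromethyl)furan-2-yl in place of isobutyl on a saturated chain carbon bound to a nitrogen on an aromatic ring in a ring. Among the compounds with values here, no pair of measured compounds shows what this kind of change does on its own, so any expectation rests on the spread of the two numbers seen. Since compound 1 also carries an aromatic ring on a saturated carbon bound to the ring nitrogen and gives 57 nM, a large move is not expected. The step from compound 2 to compound 3 is estimated as a 1.3-fold lower number from compound 2 to compound 3 (0.10 log units; within the scatter), likely within the scatter. Compound 3 is expected to give about 60 nM, within a range from 20 nM to 200 nM.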

Compound 3, half-maximal inhibitory concentration: 13 nM
For compound 3 the middle estimate is 4.6-fold (0.66 log units) above the measured one; the measured number lies below the stated range.
By their numbers in this assay, from the lowest: compound 3; then compounds 1 and 2 (each within the scatter of the next).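

In this assay, the group on this saturated chain carbon bound to a nitrogen on an aromatic ring clearly matters: 5-(trifluoromethyl)furan-2-yl in place of isobutyl gives a 5.8-fold lower number from compound 2 to compound 3 (0.77 log units; beyond the scatter). The earlier compounds shown here could not show this, as compounds 1 and 2 differ in more than one place and no single change had been isolated. Nothing available explains why this swap lowers the number, and no measurement bears on the cause.

The furan ring, its oxygen and the trifluoromethyl group all enter together, so the compounds shown cannot divide the step among them. On these data alone, a plain furan-2-yl or a 5-methylfuran-2-yl group at the same place would begin to separate those parts, and it remains unknown whether the same swap would carry over to the core of compound 1.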